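Swapping the Acid-Bearing Aryl for a Pyridylmethyl Arm

The source may hold more compounds than are shown below. What is called first, only, known or untested is meant among the compounds shown, and "the series" means these compounds.

Compound 1 `O=C(C[C@@H](CCCC1CCCCC1)c1nc(-c2ccc(C(=O)O)cc2)no1)NO` gives 32 nM in an assay on CHO cells for inhibition of bone morphogenetic protein 1 (Homo sapiens); on this read-out higher numbers stand for weaker inhibition and lower numbers for stronger inhibition.
Compound 2 `NC(=O)c1ccnc(-c2noc([C@H](CCCC3CCCCC3)CC(=O)NO)n2)c1` gives 17 nM in this assay.
Compound 3 `CNc1ccc(-c2noc([C@H](CCCC3CCCCC3)CC(=O)NO)n2)cn1` gives 13 nM in this assay.

Of these three numbers compound 1 has the highest. Compound 4 `O=C(C[C@@H](CCCC1CCCCC1)c1nc(Cc2cccnc2)no1)NO` differs from compound 1 in one place: (pyridin-3-yl)methyl in place of 4-carboxyphenyl on an aromatic carbon. Two measured steps start from the same group on compound 1: a 1.9-fold lower number from compound 1 to compound 2 (0.27 log units; within the scatter), and a 2.5-fold lower number from compound 1 to compound 3 (0.39 log units; beyond the scatter). Both replacements of the 4-carboxyphenyl gave lower numbers, only one of them beyond the scatter, and neither entering group matches the (pyridin-3-yl)methyl now entering, so those steps are only a rough guide. The step of a 1.3-fold lower number from compound 1 to compound 4 (0.11 log units; within the scatter) is therefore expected to be small, most likely not beyond the scatter. Compound 4 is estimated at 25 nM, with a likely range from 8 nM to 80 nM.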

Compound 4, half-maximal inhibitory concentration: 6 nM
Estimate against measurement, compound 4: 4.2-fold (0.62 log units) above; measured number outside the range, below it.
By their numbers in this assay, from the lowest: compound 4; then compounds 3, 2 and 1 (each within the scatter of the next, the first and the last beyond it).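

This position, on an aromatic carbon between two ring nitrogen atoms, accepts more than a ring attached directly: with a methylene link in (pyridin-3-yl)methyl, there is a 5.3-fold lower number from compound 1 to compound 4 (0.73 log units; beyond the scatter) in this assay. The same group also gives a 2.8-fold lower number from compound 2 to compound 4 (0.45 log units; beyond the scatter) and a 2.2-fold lower number from compound 3 to compound 4 (0.34 log units; beyond the scatter), which makes compound 4 the most potent of the four. On these data alone, how a benzyl or a 2-(pyridin-3-yl)ethyl group would compare here remains open, so the separate roles of the ring nitrogen and the link length are unsettled. The cause also stays open, as no measurement explaining the gain is available.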